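The source may report more compounds than this note shows. Statements on the series, on what has been measured and on what is new or still open speak of the compounds shown alone.

Measured so far in a physicochemical assay for solubility, at pH 1.1; a higher number here means a more soluble compound, a lower number a less soluble compound:
- compound 1 `CCCN(Cc1ccc(OCCN2C(=O)CCC2=O)c(C)c1)C1c2ccc(Cl)cc2CC1C(=O)O`: 3000000 nM
- compound 2 `CCN(Cc1ccc(OCCN2C(=O)CCC2=O)c(C)c1)C(CC(=O)O)c1ccc(Cl)cc1`: 3000000 nM

At the digits shown, compound 2 stands level with compound 1, and the two values lie within the scatter of each other. For the measured compounds named here, the series holds no measured pair that differs in one place, so no single change has yet been read directly in this assay.

The next compound is compound 3 `CCCCN(Cc1ccc(OCCN2C(=O)CCC2=O)c(C)c1)C(CC(=O)O)c1ccc(Cl)cc1`. It differs from compound 2 by ethyl in place of hydrogen on a saturated chain carbon, two bonds along the chain from an amine nitrogen. Cut one bond further out, the same difference reads ethyl to butyl.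

No step beyond the scatter is expected in this assay, and any small movement is more likely down than up. Going by the values given here, this expectation rests only on compound 2 at 3000000 nM and on the structural change, for which no measured example exists. The expected step is a 1.2-fold lower number from compound 2 to compound 3 (0.08 log units; within the scatter). For compound 3 the estimated value is 2500000 nM, with an expected range of 1000000 nM to 3500000 nM.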

Compound 3, solubility: 3000000 nM
The estimate for compound 3 lay 1.2-fold (0.08 log units) below the measured number; the range from low to high includes it.
By their numbers in this assay, from the lowest: compounds 1, 2 and 3 (each within the scatter of the next).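

For the compounds shown here, this is the only pair that differs in one place, so a single change can now be read directly in this assay: ethyl in place of hydrogen on a saturated chain carbon, two bonds along the chain from an amine nitrogen, gives no change at the digits printed from compound 2 to compound 3 (within the scatter) for this pair. At this position, then, the read-out does not separate the ethyl of compound 2 from the butyl of compound 3. No evidence is available that bears on this result.

From the compounds shown here alone, whether a longer chain than butyl, or a group of another kind at this position, such as a hydroxyl, an amine or a carboxylic acid, would read the same in this assay remains open. Also open, going by these compounds, is whether the same difference would read the same on the core of compound 1, since a single pair on one core cannot show how far this result carries.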